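A few compounds are considered here, and "the series" means these few. Any claim that something is new, unique, unknown or untested is made for them only; others in the source may bear on it.

Three compounds share one core. In a functional assay on MCF7 cells (Homo sapiens) for cytotoxicity, read by CellTiter-Glo, with a stated time of 5 days (on this read-out lower numbers stand for stronger inhibition and higher numbers for weaker inhibition), compound 1 `CC/C(=C(/c1ccc(/C=C/C(=O)O)cc1)c1ccc2[nH]ncc2c1)c1ccccc1` gives 7.2 nM, compound 2 `COCC/C(=C(/c1ccc(/C=C/C(=O)O)cc1)c1ccc2[nH]ncc2c1)c1ccccc1` gives 63 nM, and compound 3 `O=C(O)/C=C/c1ccc(/C(=C(\c2ccccc2)C2CC2)c2ccc3[nH]ncc3c2)cc1` gives 13 nM. Compound 3 thus stands second highest of the three numbers: nearest is compound 1, with a 1.8-fold higher number from compound 1 to compound 3 (0.26 log units; within the scatter) lying within the scatter, and furthest is compound 2, with a 4.8-fold lower number from compound 2 to compound 3 (0.69 log units; beyond the scatter). Compound 4 `O=C(O)/C=C/c1ccc(/C(=C(\c2ccccc2)C2CCC2)c2ccc3[nH]ncc3c2)cc1` differs from compound 3 by cyclobutyl in place of cyclopropyl on a double-bonded chain carbon bound to an aromatic carbon and a double-bonded chain carbon. Only those two steps, both changing the group at that same place, bear on this; one was within the scatter and the other modest. A carbon ring gaining one carbon is therefore expected to give a 1.2-fold higher number from compound 3 to compound 4 (0.06 log units; within the scatter), no step beyond the scatter. Compound 4 is estimated at 15 nM, with a range from 6 nM to 40 nM.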

Compound 4, half-maximal inhibitory concentration: 1.4 nM
The estimate for compound 4 lay 11-fold (1.03 log units) above the measured number; measured number outside the range, below it.
By their numbers in this assay, from the lowest: compound 4; then compounds 1 and 3 (each within the scatter of the next); then compound 2.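

At this place, on a double-bonded chain carbon bound to an aromatic carbon and a double-bonded chain carbon, one added ring carbon proves far from neutral: cyclobutyl in place of cyclopropyl gives a 9.3-fold lower number from compound 3 to compound 4 (0.97 log units; beyond the scatter), although ethyl and cyclopropyl had stayed within the scatter of each other. Cyclobutyl also separates from both open-chain groups, with a 5.1-fold lower number from compound 1 to compound 4 (0.71 log units; beyond the scatter) and a 45-fold lower number from compound 2 to compound 4 (1.65 log units; beyond the scatter). No measurement shown accounts for this gain. On these data alone, whether cyclopentyl or cyclohexyl would lower the number further stays open, as does whether an oxetane ring would keep it.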